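Swapping the aryl group on a piperazine in a T-type channel series

A few compounds are considered here, and "the series" means these few. Any claim that something is new, unique, unknown or untested is made for them only; others in the source may bear on it.

In an assay on HEK293 cells for inhibition of Voltage-dependent T-type calcium channel subunit alpha-1G (Homo sapiens), read by fluorescence, tested at 10 uM (on this read-out higher numbers stand for more inhibition at the one concentration tested (going by the name of the read-out) and lower numbers for less inhibition), compound 1 `CCCc1nc(-c2ccccc2)c(CNCCCN2CCN(c3ccccc3C(F)(F)F)CC2)o1` gives 45%. Within the data shown here, the only other measured compound, compound 2 `CCCc1nc(-c2ccccc2)c(CNCCN2CCN(c3cccc(Cl)c3)CC2)o1`, gives 51.2% in this assay, and the two numbers lie within the scatter of each other. Compound 3 `CCCc1nc(-c2ccccc2)c(CNCCCN2CCN(c3ccc(C)cc3)CC2)o1` is not yet measured; it differs from compound 1 in one place: 4-methylphenyl in place of 2-(trifluoromethyl)phenyl on an amine nitrogen in a ring. Among the measured compounds shown here, no step between measured compounds exists to anchor this change, so the step from compound 1 to compound 3 is expected to stay within the scatter, in either direction, no change at the digits printed from compound 1 to compound 3 (within the scatter). Compound 3 is therefore estimated at 45%, with a range from 20% to 70%.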

Compound 3, a percentage reported as inhibition, at one concentration (the size of the read-out at that concentration, not a potency): 53.9%
Compound 3: middle estimate off by 8.9 percentage points, on the low side; low and high end bracket the measured number.
By their numbers in this assay, from the lowest: compounds 1, 2 and 3 (each within the scatter of the next).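

In this assay, this position now has its first step: the read-out is a number 8.9 percentage points higher from compound 1 to compound 3 (within the scatter) when 4-methylphenyl takes the place of 2-(trifluoromethyl)phenyl on the amine nitrogen in the ring. The exchange removes all the fluorine from the group without moving the number beyond the scatter, so at this one concentration the two aryl groups cannot be told apart. Nothing available here gives a reason for this result and the step stands as an observation only. From the compounds shown here alone, whether a cyclohexyl group or a pyridine ring on that nitrogen would also leave the number within the scatter remains open.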